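Triazole sulfonamide series: new ether cap on compound 1

The source may hold more compounds than are shown below. What is called first, only, known or untested is meant among the compounds shown, and "the series" means these compounds.

Two compounds of the series have numbers in a functional assay on MOLT-3 cells (Homo sapiens) for cytotoxicity, read by MTT assay, with a stated time of 48 h; on this read-out higher numbers stand for weaker inhibition and lower numbers for stronger inhibition. Compound 1 `COC(=O)c1ccccc1OCc1cn(-c2ccc(S(=O)(=O)N3CCc4ccccc4C3)cc2)nn1` gives 18600 nM in this assay. Compound 2 `COc1cc2c(cc1OC)CN(S(=O)(=O)c1ccc(-n3cc(COc4ccc(C=O)cc4)nn3)cc1)CC2` gives 34100 nM in this assay. Compound 1 has the lowest of the two numbers, but compound 2 lies within the usual scatter of it, so the two cannot be ordered. Among the compounds with values here, no pair of compounds differing in one place has been measured, so the series itself gives no step size to lean on.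

Compound 3 `O=c1cc(OCc2cn(-c3ccc(S(=O)(=O)N4CCc5ccccc5C4)cc3)nn2)c2ccccc2o1` is not yet measured. It differs from compound 1 in a group of 11 heavy atoms (9 carbon, 2 oxygen; one six-membered aromatic ring of carbon only, one six-membered aromatic ring with 1 hetero atom) in place of a group of 10 heavy atoms (8 carbon, 2 oxygen; one six-membered aromatic ring of carbon only), on an oxygen on a saturated carbon. The shared core of compound 1 is otherwise kept. Both measured compounds sit at weak inhibition with different groups on that oxygen, and no step beyond the scatter is shown anywhere in the series, so the change is expected to give no step beyond the scatter in either direction. The expected step of a 1.2-fold lower number from compound 1 to compound 3 (0.07 log units; within the scatter) is therefore small. Compound 3 is estimated at 16000 nM in this assay, with a range from 5000 nM to 50000 nM.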

Compound 3, half-maximal inhibitory concentration: 80800 nM
Estimate against measurement, compound 3: 5.1-fold (0.70 log units) below, outside the stated range (above it).
By their numbers in this assay, from the lowest: compounds 1 and 2 (each within the scatter of the next); then compound 3.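

In this assay, within the data shown here, putting the group with a six-membered aromatic ring of carbon only and a six-membered aromatic ring with 1 hetero atom in place of 2-(methoxycarbonyl)phenyl, on an oxygen on a saturated carbon, gives a 4.3-fold higher number from compound 1 to compound 3 (0.64 log units; beyond the scatter) as the first step beyond the scatter. The number at this position therefore responds to the choice of group, and a change of this kind can weaken inhibition even though the two groups are close in heavy-atom count and have the same counts of hydrogen-bond donors and acceptors, with no net charge on either. Nothing at hand bears on the reason for this step.

Among these compounds, the single step cannot separate the loss of the methyl ester from the gain of the second ring, and a plain phenyl group or a carboxylic acid in place of the ester on this oxygen would help to tell these apart. As far as these compounds go, it also remains open whether any group at this position, such as a short chain ending in an amine, gives a lower number than the 2-(methoxycarbonyl)phenyl group does on this core.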